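The source may hold more compounds than are shown below. What is called first, only, known or untested is meant among the compounds shown, and "the series" means these compounds.

In a functional assay on HEK293 cells for negative allosteric modulation of metabotropic glutamate receptor 5 (Homo sapiens), read by FLIPR and calcium flux (a lower number here means a stronger inhibitor, a higher number a weaker inhibitor), compound 1 `Cc1cccc(NC(=O)c2nn(C)c(C3CCCCC3)c2C)n1` gives 25 nM, and compound 2 `Cc1nc(C(=O)Nc2cccc(C#N)n2)c(C)n1-c1ccc(F)cc1` gives 77 nM.

Compound 2 has the higher of the two numbers; the lower number of compound 1 lies apart from it by more than the usual scatter, so compound 2 is the weaker inhibitor of the pair. Compound 3 `Cc1nc(C(=O)Nc2ccnc(Cl)n2)c(C)n1-c1ccc(F)cc1` keeps the core of compound 2 and changes one group: 2-chloropyrimidin-4-yl in place of 6-cyanopyridin-2-yl on an amide-type nitrogen. For the measured compounds named here, no measured pair shows this exchange, so its effect cannot be read from the data. A modest step toward a higher number is expected, a 1.9-fold higher number from compound 2 to compound 3 (0.29 log units; within the scatter). The estimated value for compound 3 in this assay is 150 nM, with a range from 50 nM to 500 nM.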

Compound 3, half-maximal inhibitory concentration: 40.4 nM
Estimate against measurement, compound 3: 3.7-fold (0.57 log units) above, outside the stated range (below it).
By their numbers in this assay, from the lowest: compounds 1, 3 and 2 (each within the scatter of the next, the first and the last beyond it).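

In this assay, putting 2-chloropyrimidin-4-yl in place of 6-cyanopyridin-2-yl on the amide-type nitrogen gives a 1.9-fold lower number from compound 2 to compound 3 (0.28 log units; within the scatter) and so leaves the two compounds indistinguishable in this measurement. This position on the core of compound 2 therefore accepts a chlorine-bearing ring with two ring nitrogens as readily as a nitrile-bearing ring with one. Nothing measured here explains this match. Still open, on these data alone, is whether a methoxy group or an amine in place of the chlorine would give a similar number, and whether 2-chloropyrimidin-4-yl would behave the same way on the core of compound 1.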